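This account rests on a few compounds, and the source may have more. Where it says the series, first, only, none or still open, it means among the compounds named here.

Three compounds have been measured in a functional assay on SNO cells (Homo sapiens) for cytotoxicity, read by XTT assay, with a stated time of 24 h; a higher number here means a weaker inhibitor, a lower number a stronger inhibitor:

Compound 1 `Cc1cc(O)c2c(c1F)C(=O)C=CC2=O` gives 18900 nM
Compound 2 `CC(=O)Oc1c(C)cc(Cl)c2c1C(=O)C=CC2=O` gives 28600 nM
Compound 3 `CCOc1cc(C)cc2c1C(=O)C=CC2=O` gives 25300 nM

All three share the same core and sit close together. Compound 2 has the highest number of the three, but its gaps to compound 3 and to compound 1 both lie within the usual scatter of repeated measurements, so none of the three can be singled out as stronger or weaker than the others.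

Compound 4 `COc1c(C)cc(Cl)c2c1C(=O)C=CC2=O` has not yet been measured in this assay. It differs from compound 2 in one place: methyl in place of acetyl on an oxygen on an aromatic ring. Within the data shown here, no pair of measured compounds shows what this particular change does, so there is no measured step to lean on. With the three measured values so tightly grouped, and the change being a small one on the same core, no step beyond the scatter is expected in either direction. The estimated step from compound 2 to compound 4 is a 1.1-fold lower number from compound 2 to compound 4 (0.06 log units; within the scatter). Compound 4 is accordingly expected to give about 25000 nM, with a likely range from 10000 nM to 60000 nM.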

Compound 4, half-maximal inhibitory concentration: 44900 nM
Compound 4: the middle estimate sits 1.8-fold (0.25 log units) below what was measured, within the range that was stated.
By their numbers in this assay, from the lowest: compounds 1, 3, 2 and 4 (each within the scatter of the next, the first and the last beyond it).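

In this assay, among these compounds, replacing acetoxy with methoxy on this oxygen gives a 1.6-fold higher number from compound 2 to compound 4 (0.20 log units; within the scatter) and is the only measured one-place step in the set. Acetyl and methyl therefore cannot be told apart at this position on this core, even though the change removes a carbonyl and a hydrogen-bond acceptor. Nothing on hand speaks to why this change behaves as it does.

A single pair cannot show whether the same swap would give a similar step with the other groups on the shared core left different. From the compounds shown here alone, it also remains open what a propyl or longer chain on this oxygen would do, or an amine or a carboxylic acid carried at the end of such a chain.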